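The source may report more compounds than this note shows. Statements on the series, on what has been measured and on what is new or still open speak of the compounds shown alone.

The measured compounds in a toxicity assay on THP-1 cells (Homo sapiens) for inhibition; on this read-out lower numbers stand for higher toxicity in this test and higher numbers for lower toxicity in this test:

Compound 1, `Cn1c(-c2ccccc2Cl)cnc1NC(=O)c1ncc[nH]1`. In this assay compound 1 gives > 50000 nM, which is a limit of the assay and not a number.
Compound 2, `COc1ccc(-c2cnc(NC(=O)c3cnco3)n2C)cc1`. In this assay compound 2 gives > 100000 nM, likewise a limit and not a number.
Compound 3, `Cn1c(-c2ccc(Cl)cc2)cnc1NC(=O)c1ncc[nH]1`. In this assay compound 3 gives 52000 nM.

Compound 2 therefore stands at a limit in this assay, the only entry at the limit of > 100000 nM in this assay, at which 1 of the 3 values shown sits, while one other entry sits at the limit of > 50000 nM in this assay, at which 1 of the 3 values shown sits, so compound 3 alone has a true number. Compound 4, `COc1ccc(-c2cnc(NC(=O)c3ccncc3)n2C)cc1`, differs from compound 2 by pyridin-4-yl in place of 1,3-oxazol-5-yl on a carbonyl carbon. Within the data shown here, the single measured step among the three compounds is a step that the limit leaves unreadable from compound 1 to compound 3; it concerns a different place in the molecule and is left unreadable by the limit, so no measured step bears on the exchange at the carbonyl carbon. With nothing to argue for a shift in either direction, the step from compound 2 to compound 4 in this assay is expected to be none beyond the scatter, and compound 4 is expected to remain at or near the limit. Compound 4 is therefore estimated at 100000 nM, in the range 40000 nM to 250000 nM. The expected step is a number no higher from compound 2 to compound 4 (the limit leaves the size open).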

Compound 4, half-maximal cytotoxic concentration: > 100000 nM
Compound 4: no number, only a limit; the forecaster's own chance of this, stated with the estimate: 70%; the middle value sits exactly at the limit.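

In this assay compound 4 gives > 100000 nM, a limit of the assay and not a number. Among these compounds, compound 2 also stands at a limit, so no step between compound 2 and compound 4 can be read. The compounds shown leave open whether pyridin-4-yl and 1,3-oxazol-5-yl on the carbonyl carbon differ at all in this assay.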